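Replacing the Carbonyl-Bound Ring of Compound 2

The source may report more compounds than this note shows. Statements on the series, on what has been measured and on what is new or still open speak of the compounds shown alone.

Compound 1 `COc1ccc(Cl)cc1C(=O)NCCC1CCN(S(=O)(=O)NC(=O)NC2CCCCC2)CC1`: 25%
Compound 2 `COc1ccc(Cl)cc1C(=O)NCCC1CCN(S(=O)(=O)NC(=O)NC[C@@H]2C[C@@H]3C=C[C@@H]2C3)CC1`: 37%
Compound 3 `COc1ccc(Cl)cc1C(=O)NCCC1CCN(S(=O)(=O)NC(=O)NC[C@H]2C[C@@H]3CC[C@@H]2O3)CC1`: 27%

In a functional assay on the whole organism (blood) with Rattus norvegicus as the target, with stated times of 24 h and 1 h, at a dose of 5 mg/kg by the intraperitoneal route (a lower number here means a weaker effect, a higher number a stronger effect of the compound at the dose given), compound 2 has the highest number of the three, separated from compound 1 by a number 12 percentage points higher from compound 1 to compound 2 (beyond the scatter) but from compound 3 only by a number 10 percentage points lower from compound 2 to compound 3 (within the scatter), a gap within the scatter. Compound 4 `Cc1cccc(C(=O)NCCC2CCN(S(=O)(=O)NC(=O)NC[C@@H]3C[C@@H]4C=C[C@@H]3C4)CC2)n1` is the next compound: 6-methylpyridin-2-yl in place of 5-chloro-2-methoxyphenyl on a carbonyl carbon. All three measured steps alter the group on the amide-type nitrogen at the far end of the shared core, so none of them bears on a change at the carbonyl carbon. Among the compounds with values here, with no comparable step to lean on, the expected change is a number 2 percentage points lower from compound 2 to compound 4 (within the scatter), none beyond the scatter, with a wide range. Compound 4 is therefore estimated at 35%, between 15% and 55%.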

Compound 4, a percentage reported as activity, at one dose (the size of the read-out at that dose, not a potency): 20%
Compound 4: the middle estimate sits 15 percentage points above what was measured; measured number inside the range.
By their numbers in this assay, from the lowest: compounds 4, 1, 3 and 2 (each within the scatter of the next, the first and the last beyond it).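

Within the data shown here, this is the first step at the carbonyl carbon: in this assay, 6-methylpyridin-2-yl in place of 5-chloro-2-methoxyphenyl gives a number 17 percentage points lower from compound 2 to compound 4 (beyond the scatter), with the rest of the molecule unchanged. The group on the carbonyl carbon therefore affects the read-out at this dose, just as the group on the amide-type nitrogen did in the step from compound 1 to compound 2. No measurement here accounts for this step.

The swap replaces the whole group, leaving open whether the chlorine, the methoxy, the pyridine nitrogen or the methyl matters. A plain phenyl at this position remains an open comparison.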